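Swapping the Acyl Group on a Benzothiazolyl Thiourea

This account rests on a few compounds, and the source may have more. Where it says the series, first, only, none or still open, it means among the compounds named here.

Measured compounds:
Compound 1 `Nc1ccc2sc(NC(=S)NC(=O)c3ccccc3)nc2c1` gives 38600 nM in a functional assay on MCF7 cells (Homo sapiens) for cytotoxicity, read by MTT assay, with a stated time of 24 h; on this read-out higher numbers stand for weaker inhibition and lower numbers for stronger inhibition.
Compound 2 `O=C(NC(=S)Nc1nc2cc(Br)ccc2s1)N1CCOCC1` gives 18100 nM in this assay.

Of the two numbers in hand, compound 2 stands at the lower one, and the gap to compound 1 is beyond the usual scatter, so compound 2 is the stronger inhibitor of the pair. Compound 3 `O=C(NC(=S)Nc1nc2cc(Br)ccc2s1)c1cccs1` has not yet been measured. It differs from compound 2 in one place: thiophen-2-yl in place of morpholin-4-yl on a carbonyl carbon. Both acyl groups sit on the same carbonyl carbon of the thiourea, and the shared core with its bromine is unchanged. Going by the values given here, no step between two measured compounds tracks this particular exchange, so the guide is thin. The expectation is that the step from compound 2 to compound 3 in this assay is small, a 1.1-fold higher number from compound 2 to compound 3 (0.04 log units; within the scatter), with no clear direction beyond the scatter. Compound 3 is therefore estimated at 20000 nM, within a range of 6000 nM to 60000 nM.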

Compound 3, half-maximal inhibitory concentration: 24200 nM
Compound 3: the middle estimate sits 1.2-fold (0.08 log units) below what was measured; low and high end bracket the measured number.
By their numbers in this assay, from the lowest: compounds 2, 3 and 1 (each within the scatter of the next, the first and the last beyond it).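

In this assay, the acyl group on the thiourea now gets its first direct test, and the step is a 1.3-fold higher number from compound 2 to compound 3 (0.13 log units; within the scatter), so the two compounds cannot be told apart. On this carbonyl carbon, a five-membered aromatic ring with a sulfur atom therefore reads the same as a six-membered non-aromatic ring with two hetero atoms, at least for this pair of groups with the bromine-bearing core held fixed. Nothing measured here offers an explanation for why these two groups read alike.

Going by these compounds, whether an open-chain group such as dimethylamino or a straight alkyl chain on the same carbonyl carbon would also read alike remains open. Compound 1 differs from both compounds in more than one place, so it cannot show what its benzoyl group contributes alone.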